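This account rests on a few compounds, and the source may have more. Where it says the series, first, only, none or still open, it means among the compounds named here.

Three compounds have been measured in an assay for inhibition of Fatty-acid amide hydrolase 1 (Rattus norvegicus), using a Dixon plot; on this read-out higher numbers stand for weaker inhibition and lower numbers for stronger inhibition:
compound 1 `COC(=O)CCCCc1cnc(C(=O)CCCCCCc2ccccc2)o1`, 1.8 nM;
compound 2 `O=C(O)CCCCc1cnc(C(=O)CCCCCCc2ccccc2)o1`, 23.8 nM;
compound 3 `CSC(=O)CCCCc1cnc(C(=O)CCCCCCc2ccccc2)o1`, 1.8 nM.

Compound 3 stands level with compound 1 at the digits shown, and together these two give the lowest numbers of the three; compound 2 lies apart, a 13-fold lower number from compound 2 to compound 3 (1.12 log units; beyond the scatter). The step to compound 4 `O=CCCCCc1cnc(C(=O)CCCCCCc2ccccc2)o1` is hydrogen in place of methylsulfanyl on a carbonyl carbon. Going by the values given here, no measured step swaps this exact pair. The closest guide is the exchange at the same carbonyl carbon between compound 1 and compound 3, no change at the digits printed from compound 1 to compound 3 (within the scatter), whereas turning the methoxy into a hydroxy gave a 13-fold higher number from compound 1 to compound 2 (1.12 log units; beyond the scatter). The change to compound 4 removes the methylsulfanyl rather than replacing it with the hydroxy of compound 2, 23.8 nM. For compound 4 a modest step is therefore expected, a 2.2-fold higher number from compound 3 to compound 4 (0.35 log units; beyond the scatter). Compound 4 is estimated at 4 nM, with a range from 1.2 nM to 15 nM.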

Compound 4, inhibition constant: 14.6 nM
Estimate against measurement, compound 4: 3.7-fold (0.56 log units) below; the measured number falls inside the stated range.
By their numbers in this assay, from the lowest: compounds 1 and 3 (each within the scatter of the next); then compounds 4 and 2 (each within the scatter of the next).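

Hydrogen in place of methylsulfanyl gives an 8.1-fold higher number from compound 3 to compound 4 (0.91 log units; beyond the scatter), and hydrogen in place of methoxy gives an 8.1-fold higher number from compound 1 to compound 4 (0.91 log units; beyond the scatter), so the match between those two groups does not extend to every group on this carbonyl carbon. Hydrogen in place of hydroxy gives a 1.6-fold lower number from compound 2 to compound 4 (0.21 log units; within the scatter), which places the formyl and carboxylic acid compounds together, apart from compound 1 and compound 3. Nothing available here explains this split.

On these data alone, it remains open whether an ethoxy group or an amine on this carbonyl carbon would side with compound 1 and compound 3 or with compound 2 and compound 4.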